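The source may report more compounds than this note shows. Statements on the series, on what has been measured and on what is new or still open speak of the compounds shown alone.

Of the compounds shown here, three with a shared core have been tested in a functional assay on HeLa cells (Homo sapiens) for inhibition, with a stated time of 48 h, tested at 50 uM; a lower number here means less inhibition of growth, a higher number more inhibition of growth at the concentration tested: compound 1 (`C=C[C@@](C)(/C=C/c1ccc(OC(C)=O)cc1)CCC=C(C)C`) gives 63%, compound 2 (`C=C[C@@](C)(/C=C/c1ccc(OC(=O)CC)cc1)CCC=C(C)C`) gives 48%, and compound 3 (`C=C[C@@](C)(/C=C/c1ccc(OC(=O)CCCCC)cc1)CCC=C(C)C`) gives 50%. The data place compound 3 close to one of the others and clear of the other. They show a number 2 percentage points higher from compound 2 to compound 3 (within the scatter), and they also show a number 13 percentage points lower from compound 1 to compound 3 (beyond the scatter).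

Compound 4 (`C=C[C@@](C)(/C=C/c1ccc(OC(=O)CCCCCCC)cc1)CCC=C(C)C`) has not yet been measured. It differs from compound 3 by a single change: ethyl in place of hydrogen on a saturated chain carbon, five bonds along the chain from a carbonyl carbon.

Among the compounds with values here, the closest precedent is the extension of the same chain further out, where the data show a number 2 percentage points higher from compound 2 to compound 3 (within the scatter), even though that step adds propyl rather than ethyl. Within the data shown here, the only larger change is a number 15 percentage points lower from compound 1 to compound 2 (beyond the scatter), and it lies at the short end of the chain, so it bears less directly on this change. One precedent is thin support, but no step beyond the scatter is expected in either direction. The expected change is a number 3 percentage points lower from compound 3 to compound 4 (within the scatter). The estimate for compound 4 is 47%, with an expected range from 35% to 59%.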

Compound 4, percent growth inhibition at one concentration: 53%
Compound 4: middle estimate off by 6 percentage points, on the low side, and the stated range covers the measured number.
By their numbers in this assay, from the lowest: compounds 2, 3, 4 and 1 (each within the scatter of the next, the first and the last beyond it).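

In this assay the ethyl placed on a saturated chain carbon, five bonds along the chain from a carbonyl carbon, gives a number 3 percentage points higher from compound 3 to compound 4 (within the scatter) and so a further extension this far out, like the propyl step before it, cannot be told apart from no change. Taken together, the extensions beyond compound 2 give a number 5 percentage points higher from compound 2 to compound 4 (within the scatter) which shows that even their combined step stays inside the scatter. The new point lies in the comparison with the shortest chain: the hexyl step gives a number 10 percentage points lower from compound 1 to compound 4 (within the scatter) whereas compound 2 and compound 3 each stand beyond the scatter from compound 1, so that separation does not extend to compound 4.

Nothing available here explains how chain length relates to growth inhibition. The compounds shown also leave open whether a still longer chain, a branched chain or a chain ending in a carboxylic acid would stay within the scatter of compound 4, and whether an amide in place of the ester link would preserve the growth inhibition seen here.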